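Swapping the aryl group on the piperazine of compound 1

A few compounds are considered here, and "the series" means these few. Any claim that something is new, unique, unknown or untested is made for them only; others in the source may bear on it.

Measured so far:
- compound 1, `CCC1(C)CC(=O)N(CC(=O)N2CCN(c3ccccc3Cl)CC2)C1=O`: 122 mg/kg
- compound 2, `CC1CC(=O)N(CC(=O)N2CCN(c3cccc(Cl)c3)CC2)C1=O`: 82.7 mg/kg

Both compounds were tested in a functional assay on the whole organism (strain CD1) with Mus musculus as the target, in the maximal electroshock model; on this read-out lower numbers stand for an effect already at smaller amounts and higher numbers for an effect only at larger amounts of compound. Compound 1 gives 122 mg/kg and compound 2 gives 82.7 mg/kg; compound 1 holds the higher of the two numbers, but the gap to compound 2 lies within the scatter, so the two cannot be told apart.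

Compound 3, `CCC1(C)CC(=O)N(CC(=O)N2CCN(c3ccc(F)cc3)CC2)C1=O`, is built on the core of compound 1 with one change: 4-fluorophenyl in place of 2-chlorophenyl on an amine nitrogen in a ring. Among the compounds with values here, no measured pair shows what this kind of exchange does on its own, so nothing from the data argues for a step beyond the scatter in either direction. The expectation is therefore a number close to that of compound 1, with a step from compound 1 to compound 3 of a 1.1-fold lower number from compound 1 to compound 3 (0.04 log units; within the scatter) in this assay. Compound 3 is estimated at 110 mg/kg, with a likely range from 55 mg/kg to 220 mg/kg.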

Compound 3, dose for half-maximal effect: 69.1 mg/kg
Beside the measured number, compound 3's estimate is 1.6-fold (0.20 log units) above it; the measured number falls inside the stated range.
By their numbers in this assay, from the lowest: compounds 3, 2 and 1 (each within the scatter of the next).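

In this assay, 4-fluorophenyl in place of 2-chlorophenyl on the amine nitrogen in the ring gives a 1.8-fold lower number from compound 1 to compound 3 (0.25 log units; within the scatter) and makes this the first pair shown that differs in one place. On this evidence, the two aryl groups cannot be told apart at this position, even though the halogen and its place on the phenyl ring both differ. Nothing measured here offers an explanation for this result.

The pair leaves open what the identity of the halogen and its place on the phenyl ring each contribute alone, as the two differ together. It also leaves open how this position would respond to a different kind of group, such as a methoxy-substituted phenyl, a pyridine ring or a benzyl group.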